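Swapping a benzyl substituent: what solubility to expect

This account rests on a few compounds, and the source may have more. Where it says the series, first, only, none or still open, it means among the compounds named here.

Measured compounds in a physicochemical assay for solubility, using the shake flask method, in simulated intestinal fluid, measured as kinetic solubility, with a stated time of 2 h, at 25 degrees C, at pH 6.5; on this read-out higher numbers stand for higher solubility and lower numbers for lower solubility:
- compound 1, `CCOC(=O)c1nc(C)c2c(c1N)C(=O)N(Cc1ccccc1)C2=O`: < 5000 nM
- compound 2, `Cc1noc(-c2nc(C)c3c(c2N)C(=O)N(Cc2ccc(-c4ccncc4)cc2)C3=O)n1`: < 5000 nM
- compound 3, `Cc1noc(-c2nc(C)c3c(c2N)C(=O)N(Cc2ccc(C(F)(F)F)cc2)C3=O)n1`: < 5000 nM

Each of these three values is a limit of this assay rather than a measured number. Within the data shown here, compound 3 therefore stands only at the limit, and the two other values shown are limits as well, so no compound can be placed above or below another. Among the measured compounds shown here, the one step between measured compounds, a step that the two limits leave unreadable from compound 2 to compound 3, is likewise unreadable, and it is noted that all three values sit at the same limit (the limit of < 5000 nM in this assay, at which 3 of the 3 values shown sit).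

Compound 4, `COc1ccccc1CN1C(=O)c2c(C)nc(-c3nc(C)no3)c(N)c2C1=O`, differs from compound 3 by 2-methoxyphenyl in place of 4-(trifluoromethyl)phenyl on a saturated chain carbon bound to an amide-type nitrogen in a ring. For the measured compounds named here, no measured step bears on this change, since the only step available, from compound 2 to compound 3, could not be read. With every value shown at the limit, the size and direction of the step from compound 3 to compound 4 cannot be inferred from the data; it is therefore expected to be modest, as an estimated step that the limit leaves unreadable from compound 3 to compound 4. Compound 4 is estimated to give 4000 nM, with a likely range from 1000 nM to 15000 nM, and a fair chance that this assay again reports only a limit.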

Compound 4, solubility: < 5000 nM
Compound 4: only a limit was reported (the forecaster's own chance of this, stated with the estimate: 60%); the middle value lies beyond the limit too.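

Compound 4 also gives only a limit in this assay, so the change from compound 3 to compound 4 cannot be read, and all the values shown stand at one limit: the limit of < 5000 nM in this assay, at which 4 of the 4 values shown sit.

The compounds shown leave open how soluble each one actually is, and whether changing the benzyl substituent shifts solubility at all.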